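Swapping an aryl group on a pyridine core

A few compounds are considered here, and "the series" means these few. Any claim that something is new, unique, unknown or untested is made for them only; others in the source may bear on it.

Compound 1 `COc1ccc(-c2cc(-c3ccc(F)cc3)c(C#N)c(OC)n2)cc1`: 1360 nM
Compound 2 `COCCOc1nc(-c2ccccc2)cc(-c2ccc(F)cc2)c1C#N`: 123 nM

In an assay on isolated protein for inhibition of sulfide:quinone oxidoreductase, mitochondrial (Homo sapiens) (a lower number here means a stronger inhibitor, a higher number a weaker inhibitor), compound 1 gives 1360 nM, the higher of the two numbers, with compound 2 showing the lower figure at 123 nM; the two are separated by more than the usual scatter. Compound 3 `COc1nc(-c2ncccc2C)cc(-c2ccc(F)cc2)c1C#N` is not yet measured. It differs from compound 1 by the change (3-methylpyridin-2-yl in place of 4-methoxyphenyl on an aromatic carbon), the new group sitting next to the ring nitrogen of the shared core. Within the data shown here, no pair of measured compounds shows this kind of change, so the direction is uncertain; a modest gain toward a lower number in this assay is expected, a 1.7-fold lower number from compound 1 to compound 3 (0.23 log units; within the scatter). For compound 3 the estimate is 800 nM, within 200 nM to 3000 nM.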

Compound 3, half-maximal inhibitory concentration: 8.7 nM
Estimate against measurement, compound 3: 92-fold (1.96 log units) above; the measured number lies below the stated range.
By their numbers in this assay, from the lowest: compound 3; then compound 2; then compound 1.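

Placing 3-methylpyridin-2-yl instead of 4-methoxyphenyl on the aromatic carbon next to the ring nitrogen gives a 160-fold lower number from compound 1 to compound 3 (2.19 log units; beyond the scatter) in this assay, so the group at this position can strongly change the number in this assay. Compound 1 and compound 2 differ in more than one place and could not show this for a single position. Nothing measured here accounts for the size of the step.

From the compounds shown here alone, it remains open whether the gain follows the ring nitrogen or the methyl group of the entering group. A plain pyridin-2-yl group or a 2-methylphenyl group at this position would separate the two.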